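Trimming an oxime ether back to the free oxime

The source may report more compounds than this note shows. Statements on the series, on what has been measured and on what is new or still open speak of the compounds shown alone.

Of the compounds shown here, three have been measured in a functional assay (blood) for inhibition, with Homo sapiens as the target (a higher number here means a weaker inhibitor, a lower number a stronger inhibitor), and the one with the best number is compound 1 `COC1(c2cc(F)cc(Sc3ccc4c(c3)CC/C4=N\OCC#N)c2)CCOCC1`, which gives 30 nM. Its nearest neighbour is compound 2 `C/C(=N\OCCSc1nnnn1C)c1ccc(Sc2cc(F)cc(C3CCOCC3)c2)cc1`, which gives 120 nM, a gap that lies beyond the scatter of repeat measurements. Furthest away is compound 3 `CC(C)/C(=N\O)c1ccc(Sc2cc(F)cc(C3CCOCC3)c2)cc1`, which gives 300 nM, also well beyond the scatter. Going by the values given here, compounds 2 and 3 share a core with each other but not with compound 1, so no single structural step connects them, and only their numbers can be compared.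

The next compound, compound 4 `COC1(c2cc(F)cc(Sc3ccc4c(c3)CC/C4=N\O)c2)CCOCC1`, keeps the whole core of compound 1 and changes one spot: hydrogen in place of cyanomethyl on an oxygen. Seen one bond further out, a cyanomethoxy group becomes a hydroxy group, so the oxime loses its chain and stands bare.

Among the compounds with values here, no measured pair shows this exact change. Compound 3 carries a bare oxime and has the weakest number, but its different core means this is not a test of the change itself. The step from compound 1 to compound 4 in this assay is therefore expected to be modest, running toward a weaker inhibitor, a 2.7-fold higher number from compound 1 to compound 4 (0.43 log units; beyond the scatter). Compound 4 is estimated at 80 nM, within a range from 30 nM to 250 nM.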

Compound 4, half-maximal inhibitory concentration: 290 nM
Estimate against measurement, compound 4: 3.6-fold (0.56 log units) below; the measured number lies above the stated range.
By their numbers in this assay, from the lowest: compound 1; then compound 2; then compounds 4 and 3 (each within the scatter of the next).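

On the core of compound 1, what sits on the oxime oxygen clearly matters in this assay, and replacing cyanomethyl with hydrogen gives a 9.7-fold higher number from compound 1 to compound 4 (0.99 log units; beyond the scatter), well beyond the scatter of repeat measurements. The earlier compounds shown here could not show this, as their oxime groups sat on different cores and only their numbers could be set side by side; here the rest of the molecule is held fixed, so the whole step belongs to this one spot. Nothing measured in this set says why the step is this large.

On these data alone, with only cyanomethyl and hydrogen on this oxygen of this core, it remains open whether the nitrile itself counts or whether any chain would do, a question that a plain ethyl group in the same place could help to settle. As far as these compounds go, it also remains open whether a methyl group, a longer chain, or a chain ending in an amine or a carboxylic acid would match or improve on compound 1, which gives 30 nM in this assay as the number to beat.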